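The source may hold more compounds than are shown below. What is called first, only, known or untested is meant among the compounds shown, and "the series" means these compounds.

In a study of small cyanoaziridine ureas, compound 1 `N#CC1CN1C(=O)Nc1ccc(Cl)cc1Cl` was tested in a functional assay on A-375 cells (Homo sapiens) for inhibition (on this read-out lower numbers stand for stronger inhibition and higher numbers for weaker inhibition), where compound 1 gave only a limit of the assay, > 39000 nM. Compound 2 `CCCCNC(=O)N1CC1C#N` gave 15000 nM in this assay, and compound 3 `CC(=O)c1cccc(NC(=O)N2CC2C#N)c1` gave 7900 nM; the numbers for compound 2 and compound 3 sit within the scatter of each other, so they cannot be told apart. Compound 4 `CNC(=O)N1CC1C#N` differs from compound 2 in one place, (hydrogen in place of propyl on a saturated chain carbon bound to an amide-type nitrogen), which cut one bond further out reads butyl to methyl. Compound 4 has not yet been measured in this assay. With the nearest neighbours already weak, the step of a 2.0-fold higher number from compound 2 to compound 4 (0.30 log units; within the scatter) is expected to run toward a higher number, beyond the scatter, and compound 4 is estimated at 30000 nM, within a range from 10000 nM to 90000 nM.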

Compound 4, half-maximal inhibitory concentration: 17000 nM
For compound 4 the middle estimate is 1.8-fold (0.25 log units) above the measured one; the range from low to high includes it.
By their numbers in this assay, from the lowest: compounds 3, 2 and 4 (each within the scatter of the next, the first and the last beyond it). At a limit, above all of these: compound 1.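

In this assay, hydrogen in place of propyl on a saturated chain carbon bound to an amide-type nitrogen gives a 1.1-fold higher number from compound 2 to compound 4 (0.05 log units; within the scatter). Read as butyl to methyl, this is the first one-place comparison in the series, and it shows that compound 2 and compound 4 cannot be told apart, so shortening the chain by this much has no measurable consequence on this read-out. Nothing given here bears on why this is so. Going by these compounds, what remains open is whether a longer chain, a terminal amine or a carboxylic acid at this place would give a number beyond the scatter. The effect of hydrogen on the urea's substituted end itself also stays unresolved.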